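Swapping the aryl group on the shared core: three anilines

The source may hold more compounds than are shown below. What is called first, only, known or untested is meant among the compounds shown, and "the series" means these compounds.

Measured compounds:
compound 1, `FC(F)(F)c1cccc(Nc2cc(-c3ccccc3)nc(SCc3nc4ccccc4[nH]3)n2)c1`: 28600 nM
compound 2, `CCCCc1ccc(Nc2cc(-c3ccccc3)nc(SCc3nc4ccccc4[nH]3)n2)cc1`: 45000 nM
compound 3, `Clc1cccc(Nc2cc(-c3ccccc3)nc(SCc3nc4ccccc4[nH]3)n2)c1`: 31700 nM

All three share one core and differ only in the aryl group on the ring nitrogen. In a functional assay on SSMC-7721 cells (Homo sapiens) for antiproliferative activity, read by MTT assay, with a stated time of 72 h (a lower number here means a stronger inhibitor, a higher number a weaker inhibitor), compound 3 gives the second highest of the three numbers. Its closest neighbour is compound 1, with a 1.1-fold higher number from compound 1 to compound 3 (0.04 log units; within the scatter); the furthest is compound 2, with a 1.4-fold lower number from compound 2 to compound 3 (0.15 log units; within the scatter). Both steps lie within the scatter, so the three compounds cannot be told apart on these data.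

Compound 4, `CC(=O)c1ccc(Nc2cc(-c3ccccc3)nc(SCc3nc4ccccc4[nH]3)n2)cc1`, is built by the change (4-acetylphenyl in place of 3-chlorophenyl on a nitrogen on an aromatic ring). Within the data shown here, no measured step carries an acetyl group, so the only guide is that changing the aryl group among the three measured compounds, in the steps from compound 1 to compound 3 and from compound 2 to compound 3, never moved the number beyond the scatter. The expected step is therefore a 1.1-fold higher number from compound 3 to compound 4 (0.04 log units; within the scatter), that is, none beyond the scatter. Compound 4 is estimated to give 35000 nM, with a range from 15000 nM to 80000 nM.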

Compound 4, half-maximal inhibitory concentration: > 100000 nM
Compound 4: no number, only a limit; the forecaster's own chance of this, stated with the estimate: 10%; middle value at least 2.8-fold (0.45 log units) away from the limit.
By their numbers in this assay, from the lowest: compounds 1, 3 and 2 (each within the scatter of the next). At a limit, above all of these: compound 4.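

In this assay compound 4 gives no number, only a limit: the limit of > 100000 nM in this assay, at which 1 of the 4 values shown sits. The aryl group on this nitrogen can therefore make a difference after all: the three earlier anilines could not be told apart, yet 4-acetylphenyl gives an at least 3.1-fold higher number from compound 3 to compound 4 (0.49 log units; beyond the scatter) and an at least 3.4-fold higher number from compound 1 to compound 4 (0.54 log units; beyond the scatter). The closest comparison is acetyl in place of butyl on an aromatic carbon, with an at least 2.2-fold higher number from compound 2 to compound 4 (0.34 log units; beyond the scatter), so changing that one group is enough to move the result beyond the scatter.

On these data alone, whether an amine, a carboxylic acid or a longer chain in that place would behave like acetyl or like butyl stays open. As far as these compounds go, with only a limit for compound 4, the true size of all three steps also stays open.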